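The source may report more compounds than this note shows. Statements on the series, on what has been measured and on what is new or still open speak of the compounds shown alone.

Measured in a functional assay on HepG2 cells (Homo sapiens) for cytotoxicity, read by MTT assay, with a stated time of 72 h; on this read-out lower numbers stand for higher toxicity in this test and higher numbers for lower toxicity in this test:

Compound 1 `Nc1cc(C(F)(F)F)cc2c1SSSSS2`: 26600 nM
Compound 2 `O=C(CN1CCCCC1)Nc1cc(C(F)(F)F)cc2c1SSSSS2`: 24400 nM

Compound 2 gives 24400 nM, which lies within the usual scatter of compound 1 at 26600 nM, so the two cannot be told apart on these numbers. The next compound, compound 3 `CCCCN(CCCC)CC(=O)Nc1cc(C(F)(F)F)cc2c1SSSSS2`, has not yet been measured. It differs from compound 2 in one place: dibutylamino in place of piperidin-1-yl on a saturated chain carbon bound to a carbonyl carbon. In words, this is dibutylamino in place of piperidin-1-yl on a saturated chain carbon bound to a carbonyl carbon. Within the data shown here, no measured pair differs in a single place, so the data offer no direct guide to this change. A large shift in this assay is not expected, since compound 2 at 24400 nM sits level with compound 1 at 26600 nM. The estimated step of a 1.2-fold lower number from compound 2 to compound 3 (0.09 log units; within the scatter) is small and stays within the scatter. For compound 3 the estimate is 20000 nM, with an expected range from 8000 nM to 48000 nM.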

Compound 3, half-maximal cytotoxic concentration: > 100000 nM
Compound 3 gave a limit, no number; the forecaster's own chance of this, stated with the estimate: 10%; middle value at least 5.0-fold (0.69 log units) from the limit.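

In this assay, compound 3 gives > 100000 nM, which is a limit of the assay and not a number. Dibutylamino in place of piperidin-1-yl on a saturated chain carbon bound to a carbonyl carbon brings an at least 4.0-fold higher number from compound 2 to compound 3 (0.61 log units; beyond the scatter), which means lower toxicity in this test and gives the first evidence that the group at this position can change the read-out. The full size of the step stays unknown because it rests on a limit: the limit of > 100000 nM in this assay, at which 1 of the 3 values shown sits.

The change removes a ring and also adds heavy atoms, so these compounds cannot show which of the two matters. Also open, going by these compounds, is how diethylamino, with its shorter chains, or morpholin-4-yl, which keeps a ring, would read in this assay.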